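Compound 4 as a dimethoxyphenyl variant of compound 1

The source may report more compounds than this note shows. Statements on the series, on what has been measured and on what is new or still open speak of the compounds shown alone.

In a functional assay on HEK293 cells for antagonist activity at P2X purinoceptor 7 (Homo sapiens), read by FLIPR and calcium flux (on this read-out higher numbers stand for weaker inhibition and lower numbers for stronger inhibition), three compounds have been measured:
compound 1 `Cc1ccccc1N/C(=N\C#N)NC(NC(=O)CCCc1ccccc1)C(C)(C)C` gives 79.4 nM
compound 2 `CC(C)(C)C(NC(=O)CCCc1cccnc1)N/C(=N/C#N)Nc1cccc2ncccc12` gives 100 nM
compound 3 `Cc1ncccc1N/C(=N\C#N)NC(NC(=O)CCCCc1ccccc1)C(C)(C)C` gives 63.1 nM

Compound 1 holds the second highest of these three numbers; compound 3 lies a little lower and compound 2 a little higher, but both gaps fall within the scatter, so the three stand level. Compound 4 `COc1ccc(CCC(=O)NC(N/C(=N/C#N)Nc2ccccc2C)C(C)(C)C)cc1OC` is drawn from compound 1 by one change: 3,4-dimethoxyphenyl in place of benzyl on a saturated chain carbon, two bonds along the chain from a carbonyl carbon. Among the measured compounds shown here, no measured pair shows this change, so its size is unknown here. The expectation is that the step from compound 1 to compound 4 in this assay, a 1.4-fold higher number from compound 1 to compound 4 (0.14 log units; within the scatter), stays within the scatter or weakens inhibition only slightly. Compound 4 is therefore estimated at 110 nM, between 40 nM and 300 nM.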

Compound 4, half-maximal inhibitory concentration: 200 nM
For compound 4 the middle estimate is 1.8-fold (0.26 log units) below the measured one, and the stated range covers the measured number.
By their numbers in this assay, from the lowest: compounds 3, 1, 2 and 4 (each within the scatter of the next, the first and the last beyond it).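

In this assay the change to 3,4-dimethoxyphenyl in place of benzyl, on a saturated chain carbon two bonds along the chain from a carbonyl carbon, gives a 2.5-fold higher number from compound 1 to compound 4 (0.40 log units; beyond the scatter) and so weakens inhibition modestly, beyond the scatter. Among the compounds shown here, this is the first single-place step at this position, and it shows that the position is sensitive to this change. No evidence at hand explains the step.

The compounds shown leave open whether a single methoxy group, or a chloro or hydroxy group on that ring, would give a similar step. They also leave open whether the step would carry over to the core of compound 3.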